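The compounds below may be only part of what the source reports. "The series", "measured", "known", "first", "only" and "open" are said of these compounds alone.

Measured so far in a functional assay on the whole organism for inhibition, with Mus musculus as the target; a higher number here means that more compound is needed for the effect, a lower number that less compound is needed: compound 1 `CCN1CCCC1CNC(=O)c1cc(N(C)S(C)(=O)=O)ccc1OC` gives 22.9 mg/kg; compound 2 `CCN1CCCC1CNC(=O)c1cc(N(C)S(C)(=O)=O)c(C)cc1OC` gives 26.1 mg/kg; compound 3 `CCN1CCCC1CNC(=O)c1cc(N(C)S(=O)(=O)N(C)C)ccc1OC` gives 36.2 mg/kg.

Compound 4 `CCN1CCCC1CNC(=O)c1cc(N(C)S(=O)(=O)N(C)C)c(C)cc1OC` has not been measured. It stands to compound 3 as compound 2 stands to compound 1. The change from compound 1 to compound 2 is methyl in place of hydrogen on an aromatic carbon, and in this assay it made the step of a 1.1-fold higher number from compound 1 to compound 2 (0.06 log units; within the scatter). The two cores differ by dimethylamino in place of methyl on a sulfonyl sulfur. The change into compound 4 is methyl in place of hydrogen on an aromatic carbon; around the place, the entering methyl is ortho to a methyl(methylsulfonyl)amino group (6 heavy atoms) in compound 2 but ortho to a (dimethylsulfamoyl)(methyl)amino group (8 heavy atoms) in compound 4, so the two changes are the same kind of change, not the same. The step expected for compound 4 in this assay is a 1.1-fold higher number from compound 3 to compound 4 (0.04 log units; within the scatter), resting on the earlier step of a 1.1-fold higher number from compound 1 to compound 2 (0.06 log units; within the scatter). Compound 4 is therefore estimated at about 40 mg/kg, likely between 25 mg/kg and 65 mg/kg.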

Compound 4, dose for half-maximal effect: > 50 mg/kg
Compound 4 ended at the assay's limit; the forecaster's own chance of this, stated with the estimate: 5%; middle value at least 1.2-fold (0.09 log units) from the limit.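

In this assay compound 4 gives > 50 mg/kg, which is a limit of the assay and not a number. Read only as floors, putting methyl in place of hydrogen on the aromatic carbon gives an at least 1.3-fold higher number from compound 3 to compound 4 (0.14 log units; that floor lies within the scatter), and putting dimethylamino in place of methyl on the sulfonyl sulfur gives an at least 1.9-fold higher number from compound 2 to compound 4 (0.28 log units; that floor lies within the scatter). This shows no clear departure from the earlier steps, but it does not show that the methyl change carries over unchanged from one core to the other: the same change on two cores in this assay, a 1.1-fold higher number (0.06 log units; within the scatter) from compound 1 to compound 2 and an at least 1.3-fold higher number (0.14 log units; that floor lies within the scatter) from compound 3 to compound 4; the limit leaves it open whether they differ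

From the compounds shown here alone, how far the number of compound 4 lies past the limit stays open. Also open, going by these compounds, is how a chlorine atom or a propyl chain on that same aromatic carbon would behave on either core.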